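Ester variation on the shared core: outlook for compound 3

A few compounds are considered here, and "the series" means these few. Any claim that something is new, unique, unknown or untested is made for them only; others in the source may bear on it.

Measured compounds:
compound 1 `CCCCc1nc(C)c(CC(=O)OC(C)C)c(=O)n1Cc1ccc(-c2ccccc2-c2noc(=O)[nH]2)cc1`: 17.5%
compound 2 `CCCCc1nc(C2CC2)c(CC(=O)OC)c(=O)n1Cc1ccc(-c2ccccc2-c2noc(=O)[nH]2)cc1`: 24.4%

In an ADME assay on microsomes from liver (Homo sapiens) for metabolic stability, with a stated time of 30 min (on this read-out higher numbers stand for a more stable compound and lower numbers for a less stable compound), compound 2 gives 24.4%, the larger of the two numbers shown, yet its gap to compound 1 at 17.5% lies within the scatter and does not set the two apart. Compound 3 `CCCCc1nc(C2CC2)c(CC(=O)OC(C)C)c(=O)n1Cc1ccc(-c2ccccc2-c2noc(=O)[nH]2)cc1` differs from compound 2 by isopropyl in place of methyl on an oxygen next to a carbonyl group. For the measured compounds named here, no pair of measured compounds differs by this change alone, so its size is unknown here. The expected step from compound 2 to compound 3 is a number 3.4 percentage points lower from compound 2 to compound 3 (within the scatter), none beyond the scatter. Compound 3 is estimated at 21%, with a range from 9% to 35%.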

Compound 3, percent of the compound remaining: 9.9%
Beside the measured number, compound 3's estimate is 11.1 percentage points above it; low and high end bracket the measured number.
By their numbers in this assay, from the lowest: compounds 3, 1 and 2 (each within the scatter of the next, the first and the last beyond it).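

In this assay, isopropyl in place of methyl on an oxygen next to a carbonyl group gives a step that can be read at this position, a number 14.5 percentage points lower from compound 2 to compound 3 (beyond the scatter), with cyclopropyl on the aromatic carbon held constant. Cyclopropyl in place of methyl on an aromatic carbon, with isopropyl on the oxygen held constant, gives a number 7.6 percentage points lower from compound 1 to compound 3 (within the scatter), so only the change on the oxygen clears the scatter. Nothing available explains either step.

As far as these compounds go, whether the oxygen step recurs with methyl on the aromatic carbon remains open. So does the reading for a tert-butyl group or longer chain on that oxygen, or for a free carboxylic acid.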